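Moving the Trifluoromethyl Group on the Urea Phenyl

The compounds below may be only part of what the source reports. "The series", "measured", "known", "first", "only" and "open" are said of these compounds alone.

Two diaryl ureas built on a shared core have been tested in a functional assay on MDA-MB-231 cells (Homo sapiens) for antiproliferative activity, read by MTT assay, with a stated time of 72 h; on this read-out higher numbers stand for weaker inhibition and lower numbers for stronger inhibition. Compound 1, `CN(C)CCn1cnnc1-c1cc(Oc2ccc(NC(=O)Nc3ccccc3C(F)(F)F)cc2F)ccn1`, carries a dimethylaminoethyl chain and a 2-(trifluoromethyl)phenyl group on the urea. In this assay compound 1 reaches only a limit of the assay, > 50000 nM, not a number. Compound 2, `CCN(CC)CCn1cnnc1-c1cc(Oc2ccc(NC(=O)Nc3cccc(C(F)(F)F)c3)cc2F)ccn1`, carries a diethylaminoethyl chain and a 3-(trifluoromethyl)phenyl group; in this assay compound 2 gives 720 nM. That is the only full number shown, the other value being a limit (the limit of > 50000 nM in this assay, at which 1 of the 2 values shown sits). Compound 3, `CCN(CC)CCn1cnnc1-c1cc(Oc2ccc(NC(=O)Nc3ccccc3C(F)(F)F)cc2F)ccn1`, has not yet been measured. It differs from compound 2 in one place: 2-(trifluoromethyl)phenyl in place of 3-(trifluoromethyl)phenyl on an amide-type nitrogen. Going by the values given here, no measured pair isolates this change, so its size is not known from direct comparison; still, compound 1 also carries the 2-(trifluoromethyl)phenyl group, and its limit of > 50000 nM points toward weaker inhibition. The step is therefore expected to be a loss, a 35-fold higher number from compound 2 to compound 3 (1.54 log units; beyond the scatter), beyond the scatter. Compound 3 is expected to give about 25000 nM, within a range of 4000 nM to 60000 nM, with a fair chance that only a limit is reported.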

Compound 3, half-maximal inhibitory concentration: 11600 nM
Estimate against measurement, compound 3: 2.2-fold (0.33 log units) above, within the range that was stated.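

With the diethylaminoethyl chain held fixed, 2-(trifluoromethyl)phenyl in place of 3-(trifluoromethyl)phenyl on the urea nitrogen gives a 16-fold higher number from compound 2 to compound 3 (1.21 log units; beyond the scatter) in this assay, so the placing of the trifluoromethyl group on this phenyl ring matters a great deal, even though the two groups hold the same atoms. With 2-(trifluoromethyl)phenyl held fixed, diethylamino in place of dimethylamino gives an at least 4.3-fold lower number from compound 1 to compound 3 (0.63 log units; beyond the scatter), so the amine at the end of the chain also affects the read-out, and a compound carrying the 2-(trifluoromethyl)phenyl group can still give a full number. The size of this second step is only a bound, since compound 1 stands at a limit of the assay: the limit of > 50000 nM in this assay, at which 1 of the 3 values shown sits.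

The compounds shown leave open whether the change from dimethylamino to diethylamino would matter as much when paired with 3-(trifluoromethyl)phenyl. Also open, as far as these compounds go, is how a 4-(trifluoromethyl)phenyl group on the urea, or a pyrrolidine or morpholine at the end of the chain, would read in this assay.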